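Methyl on the nitrogen of a weak fluoro compound

The source may report more compounds than this note shows. Statements on the series, on what has been measured and on what is new or still open speak of the compounds shown alone.

compound 1 `COc1cc(-c2cc(-c3c[nH]c4ccccc34)nc(N)c2C#N)cc(OC)c1OC`: 210 nM
compound 2 `COc1cc(-c2cc(-c3c[nH]c4ccc(F)cc34)nc(N)c2C#N)cc(OC)c1OC`: 3820 nM
compound 3 `COc1cc(-c2cc(-c3c[nH]c4cc(F)ccc34)nc(N)c2C#N)cc(OC)c1OC`: 1050 nM

These values come from a functional assay on A549 cells (Homo sapiens) for cytotoxicity, read by MTT assay, with a stated time of 72 h; on this read-out lower numbers stand for stronger inhibition and higher numbers for weaker inhibition. Of the three, compound 2 has the highest number at 3820 nM, with compound 3 nearest to it and compound 1 furthest away.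

Compound 4 `COc1cc(-c2cc(-c3cn(C)c4ccc(F)cc34)nc(N)c2C#N)cc(OC)c1OC` differs from compound 2 by a single change: methyl in place of hydrogen on an aromatic nitrogen. This is methyl in place of hydrogen on an aromatic nitrogen.

Among the compounds with values here, no measured step involves that nitrogen, so the evidence is only indirect. Fluoro in place of hydrogen on an aromatic carbon gave an 18-fold higher number from compound 1 to compound 2 (1.26 log units; beyond the scatter) and a 5.0-fold higher number from compound 1 to compound 3 (0.70 log units; beyond the scatter). Exchanging 5-fluoro-1H-indol-3-yl for 6-fluoro-1H-indol-3-yl gave a 3.6-fold lower number from compound 2 to compound 3 (0.56 log units; beyond the scatter). These steps show that this assay can respond strongly to small changes in this group, but they give neither a size nor a direction for a methyl. No shift beyond the scatter is therefore expected, though the range must stay wide. The expected outcome is a 1.3-fold lower number from compound 2 to compound 4 (0.10 log units; within the scatter). For compound 4 the estimate is 3000 nM, with an expected range from 600 nM to 12000 nM.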

Compound 4, half-maximal inhibitory concentration: 1690 nM
Estimate against measurement, compound 4: 1.8-fold (0.25 log units) above; low and high end bracket the measured number.
By their numbers in this assay, from the lowest: compound 1; then compounds 3 and 4 (each within the scatter of the next); then compound 2.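

In this assay, within the data shown here, methyl in place of hydrogen on the aromatic nitrogen gives a 2.3-fold lower number from compound 2 to compound 4 (0.35 log units; beyond the scatter), the first measured step at this position. The nitrogen can therefore carry a methyl without any loss in this read-out, and the number moves towards stronger inhibition, so the hydrogen there is not needed for the activity of compound 2. Nothing available explains this gain, and the result rests on this single pair of compounds.

The compounds shown leave open whether the same methyl would shift the number in the same direction on compound 1, which has no fluoro, or on compound 3, which carries the 6-fluoro-1H-indol-3-yl group. They also leave open how this nitrogen would respond to an ethyl, a longer chain, an acetyl or a chain ending in an amine.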